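The compounds below may be only part of what the source reports. "The series", "measured", "known", "first", "only" and "open" are said of these compounds alone.

In a functional assay on MCF7 cells (Homo sapiens) for antiproliferative activity, read by MTT assay, with stated times of 24 h and 72 h (a higher number here means a weaker inhibitor, a lower number a stronger inhibitor), compound 1 `COc1ccc([C@@H]2[C@H](Oc3ccccc3)C(=O)N2c2cc(OC)c(OC)c(OC)c2)cc1[N+](=O)[O-]` gives 69000 nM and compound 2 `COc1cc(N2C(=O)[C@@H](Oc3ccccc3)[C@H]2c2ccc([N+](=O)[O-])cc2)cc(OC)c1OC` gives 63000 nM, which is a 1.1-fold lower number from compound 1 to compound 2 (0.04 log units; within the scatter). Compound 3 `COc1cc(N2C(=O)[C@@H](Oc3ccccc3)[C@H]2c2ccc([S+](C)[O-])cc2)cc(OC)c1OC` is the lowest of the three at 20000 nM, with a 3.2-fold lower number from compound 2 to compound 3 (0.50 log units; beyond the scatter) and a 3.5-fold lower number from compound 1 to compound 3 (0.54 log units; beyond the scatter). Compound 4 `COc1cc([C@@H]2[C@H](Oc3ccccc3)C(=O)N2c2cc(OC)c(OC)c(OC)c2)ccc1O` is still unmeasured. It carries 4-hydroxy-3-methoxyphenyl on the saturated ring carbon, replacing the sulfur-bearing group of compound 3: a group of 9 heavy atoms (7 carbon, 2 oxygen; one six-membered aromatic ring of carbon only) in place of a group of 9 heavy atoms (7 carbon, 1 oxygen, 1 sulfur; one six-membered aromatic ring of carbon only), on a saturated ring carbon. All three measured steps alter this same aromatic group, and none is larger than modest, but none introduces this new group. A modest step is therefore expected in this assay, probably towards a lower number, though the direction is uncertain. The expected change is a 2.5-fold lower number from compound 3 to compound 4 (0.40 log units; beyond the scatter). Compound 4 is estimated at 8000 nM, within an expected range of 1000 nM to 40000 nM.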

Compound 4, half-maximal inhibitory concentration: 32000 nM
Estimate against measurement, compound 4: 4.0-fold (0.60 log units) below, and the stated range covers the measured number.
By their numbers in this assay, from the lowest: compounds 3, 4, 2 and 1 (each within the scatter of the next, the first and the last beyond it).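

In this assay, the hydrogen-bond donor that enters with 4-hydroxy-3-methoxyphenyl on this saturated ring carbon leaves the number close to those of two earlier compounds, with a 1.6-fold higher number from compound 3 to compound 4 (0.20 log units; within the scatter) and a 2.0-fold lower number from compound 2 to compound 4 (0.29 log units; within the scatter) as the steps. Among the compounds shown here, only a 2.2-fold lower number from compound 1 to compound 4 (0.33 log units; beyond the scatter) passes the scatter, and it is modest, so this new group does not set compound 4 far apart from the earlier compounds. Nothing available here explains these steps. The compounds shown leave open how an amine or a carboxylic acid would behave on this aromatic group. They also leave open what the hydroxy and methoxy groups each contribute alone.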